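This account rests on a few compounds, and the source may have more. Where it says the series, first, only, none or still open, it means among the compounds named here.

Working notes on the series.

Going by the values given here, compound 2, `COc1cc(Cl)cc(-c2nn(-c3cccc(NC(=O)Nc4cccc(C(F)(F)F)c4)c3)cc2-c2ccncc2)c1`, stands highest of the two numbers so far: in a functional assay on RPMI-8226 cells (Homo sapiens) for inhibition, read by sulforhodamine B assay, with a stated time of 48 h (a lower number here means a stronger inhibitor, a higher number a weaker inhibitor), compound 2 gives 430 nM. Among the compounds with values here, its only neighbour is compound 1, `COc1cc(Cl)cc(-c2nn(-c3cccc(NC(=O)Nc4ccc(Cl)c(C(F)(F)F)c4)c3)cc2-c2ccncc2)c1`, which in this assay gives 400 nM; the single measured step, hydrogen in place of chloro on an aromatic carbon, is a 1.1-fold higher number from compound 1 to compound 2 (0.03 log units; within the scatter), so the two compounds sit within the scatter of each other and neither can be called the stronger.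

Compound 3, `COc1cc(Cl)cc(-c2nn(-c3cccc(NC(=O)c4cccc(C(F)(F)F)c4)c3)cc2-c2ccncc2)c1`, is the next compound for this assay. It differs from compound 2 by 3-(trifluoromethyl)phenyl in place of (3-(trifluoromethyl)phenyl)amino on a carbonyl carbon. Within the data shown here, the one measured step does not bear on this change: it touches a different part of the molecule and was itself within the scatter, so it gives no guide to the direction or size of a step at the carbonyl carbon. Among the measured compounds shown here, with no comparable step in hand, the expectation for compound 3 rests on the measured pair only as an anchor, and the range must be wide. The estimated step is a 2.1-fold higher number from compound 2 to compound 3 (0.32 log units; beyond the scatter). Compound 3 is expected to give about 900 nM, with the estimate spanning 250 nM to 3500 nM.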

Compound 3, half-maximal inhibitory concentration: 3130 nM
Compound 3: middle estimate off by 3.5-fold (0.54 log units), on the low side; measured number inside the range.
By their numbers in this assay, from the lowest: compounds 1 and 2 (each within the scatter of the next); then compound 3.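

Going by these compounds alone, putting 3-(trifluoromethyl)phenyl directly on the carbonyl carbon, in place of the (3-(trifluoromethyl)phenyl)amino group, gives the first step beyond the scatter in this assay, with a 7.3-fold higher number from compound 2 to compound 3 (0.86 log units; beyond the scatter) toward a weaker inhibitor. The comparison with the chlorinated urea points the same way, with a 7.8-fold higher number from compound 1 to compound 3 (0.89 log units; beyond the scatter), so the loss of potency does not rest on compound 2 alone. The aromatic chloro change made no readable difference between compound 1 and compound 2, whereas this change on the carbonyl carbon, which removes the amino nitrogen and its one hydrogen-bond donor, clearly does. Nothing available here gives a measured reason for the higher number.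

The compounds shown leave open whether the amino nitrogen itself or its hydrogen accounts for the step, which a methylamino, methylene or oxygen link on the same carbonyl carbon would help to separate. They also leave open whether a 4-chloro-3-(trifluoromethyl)phenyl group directly on the carbonyl carbon would sit within the scatter of compound 3, as the chloro change did among the ureas.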